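The source may report more compounds than this note shows. Statements on the series, on what has been measured and on what is new or still open speak of the compounds shown alone.

Measured so far in an ADME assay on microsomes from liver (Canis lupus familiaris) for metabolic stability, read by LC-MS, using NADPH, with a stated time of 30 min, tested at 1 uM; a lower number here means that less of the compound is left, a higher number that more of the compound is left:

Compound 1 `C=CC(=O)Nc1cc(Nc2ncc(F)c(Nc3ccccc3S(=O)(=O)N(C)C)n2)c(OC)cc1N(C)CCN(C)C`: 33%
Compound 2 `C=CC(=O)Nc1cc(Nc2ncc(Cl)c(Nc3ccccc3S(=O)(=O)C(C)C)n2)c(OC)cc1N(C)CCN(C)C`: 17%

Of these two, compound 2 stands lower, and the gap to compound 1 lies beyond the usual scatter. Compound 3 `C=CC(=O)Nc1cc(Nc2ncc(F)c(Nc3ccccc3S(=O)(=O)C(C)C)n2)c(OC)cc1N(C)CCN(C)C` has not yet been measured. It differs from compound 2 in one place: fluoro in place of chloro on an aromatic carbon. This is fluoro in place of chloro on an aromatic carbon of a six-membered aromatic ring with 2 nitrogen.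

For the measured compounds named here, no measured pair shows this exchange on its own, so any forecast rests on little. Compound 1 also carries fluoro and gives 33%, but it differs from compound 2 elsewhere too, so this value is only a weak guide. A small rise in this assay is therefore expected, one that probably stays within the scatter. The estimated change is a number 6 percentage points higher from compound 2 to compound 3 (within the scatter). For compound 3 the estimated value is 23%, with an expected range from 12% to 38%.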

Compound 3, percent of the compound remaining: 27%
The estimate for compound 3 lay 4 percentage points below the measured number; the range from low to high includes it.
By their numbers in this assay, from the lowest: compounds 2, 3 and 1 (each within the scatter of the next, the first and the last beyond it).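

In this assay, fluoro in place of chloro on an aromatic carbon of a six-membered aromatic ring with 2 nitrogen, two atoms from the ring nitrogen, can now be read on its own, with the rest of the structure held constant, and it gives a number 10 percentage points higher from compound 2 to compound 3 (within the scatter). With fluoro held at this position, the exchange of isopropyl in place of dimethylamino on a sulfonyl sulfur can be read on its own as well, and it gives a number 6 percentage points lower from compound 1 to compound 3 (within the scatter), so neither single exchange separates its pair beyond the scatter. The compounds shown offer no measured basis for explaining either step.

From the compounds shown here alone, it remains open how a nitrile or a methyl group at this position would read in this assay, since only the two halogens, chloro and fluoro, appear there. Going by these compounds, it is also open whether fluoro in place of chloro would read the same with dimethylamino on the sulfonyl sulfur, and how a cyclopropyl group on that sulfur would compare with isopropyl.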